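Removing One Methoxy Group from Compound 2

The compounds below may be only part of what the source reports. "The series", "measured", "known", "first", "only" and "open" are said of these compounds alone.

Of the compounds shown here, two have been tested in a functional assay on UO-31 cells (Homo sapiens) for cytotoxicity, read by sulforhodamine B assay, with a stated time of 48 h, tested at 1 uM; a lower number here means a stronger effect, a higher number a weaker effect of the compound at the concentration tested. Compound 1 `COc1cc(-c2cc(/C=C/C(=O)c3ccc(N)cc3)[nH]n2)cc(OC)c1OC` gives 71% in this assay. Compound 2 `COc1ccc(C(=O)/C=C/c2cc(-c3cc(OC)c(OC)c(OC)c3)n[nH]2)cc1OC` gives 67% in this assay; on the two numbers shown it holds the lower value, yet the single measured step, a number 4 percentage points lower from compound 1 to compound 2 (within the scatter), lies within the scatter, so these two compounds cannot be told apart by this assay.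

Compound 3 `COc1ccc(C(=O)/C=C/c2cc(-c3cc(OC)c(OC)c(OC)c3)n[nH]2)cc1` has not yet been measured. It differs from compound 2 in one place: hydrogen in place of methoxy on an aromatic carbon. Cut one bond further out, the same change reads as 3,4-dimethoxyphenyl becoming 4-methoxyphenyl on the carbonyl carbon.

Among the compounds with values here, no measured step touches a methoxy group. Within the data shown here, the only step measured, a number 4 percentage points lower from compound 1 to compound 2 (within the scatter), exchanges the whole aryl group on the carbonyl carbon and stays within the scatter even so. A smaller trim within that same group is therefore expected to move this assay by no more than the scatter, in either direction. Compound 3 is expected to give about 68% in this assay, most likely between 56% and 80%. That estimate means an expected step of a number 1 percentage points higher from compound 2 to compound 3 (within the scatter).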

Compound 3, a percentage reported as activity, at one concentration (the size of the read-out at that concentration, not a potency): 77%
The estimate for compound 3 lay 9 percentage points below the measured number, within the range that was stated.
By their numbers in this assay, from the lowest: compounds 2, 1 and 3 (each within the scatter of the next).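

Trimming 3,4-dimethoxyphenyl to 4-methoxyphenyl is the first change shown that touches a single methoxy group on this aromatic ring, and in this assay it gives a number 10 percentage points higher from compound 2 to compound 3 (within the scatter), so hydrogen and methoxy at this place cannot be told apart. The other single-place comparison, methoxy in place of amino on the same ring, gives a number 6 percentage points higher from compound 1 to compound 3 (within the scatter), so 4-aminophenyl, 4-methoxyphenyl and 3,4-dimethoxyphenyl on the carbonyl carbon all remain indistinguishable at this one tested concentration. No measurement shown here offers an explanation for these numbers.

The compounds shown leave open whether any substituent on this ring can move the read-out beyond the scatter, for example a carboxylic acid, a chlorine atom or a longer chain such as butoxy in place of the remaining methoxy group. Within the data shown here, they also leave open what the methoxy groups on the other aromatic ring contribute, as all three compounds carry those groups unchanged and no step here tests them.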